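Swapping One Ring Group on a Weak Compound

The source may hold more compounds than are shown below. What is called first, only, known or untested is meant among the compounds shown, and "the series" means these compounds.

Measured in a functional assay on HOS-TE85 cells (Homo sapiens) for inhibition, read by CCK-8 assay, with a stated time of 72 h; a higher number here means a weaker inhibitor, a lower number a stronger inhibitor:
- compound 1 `COc1ccc(OC)c(N2C(=O)CSC2c2cccc(C(=O)NCCCCc3ccccc3)c2)c1`: > 1000 nM (a limit, not a number)
- compound 2 `O=C(NCCCCc1ccccc1)c1cc(F)cc(C2SCC(=O)N2c2ccccn2)c1`: 14.2 nM
- compound 3 `COc1ccccc1N1C(=O)CSC1c1cc(F)cc(C(=O)NCCCCc2ccccc2)c1`: 40.9 nM

Compound 1 has no exact number, only a limit: the limit of > 1000 nM in this assay, at which 1 of the 3 values shown sits. The next compound to be tested is compound 4 `COc1cc(F)ccc1N1C(=O)CSC1c1cccc(C(=O)NCCCCc2ccccc2)c1`. It keeps the core of compound 1, but 4-fluoro-2-methoxyphenyl takes the place of 2,5-dimethoxyphenyl on the amide-type nitrogen in the ring (4-fluoro-2-methoxyphenyl in place of 2,5-dimethoxyphenyl on an amide-type nitrogen in a ring).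

For the measured compounds named here, only one measured step changes the group on this nitrogen: a 2.9-fold higher number from compound 2 to compound 3 (0.46 log units; beyond the scatter). That step is modest, and it shows that this nitrogen tolerates a change of group. Compound 3, which gives 40.9 nM, carries a methoxyphenyl group there, but it also differs from compound 4 elsewhere, so it is only a loose guide.

A move towards a lower number, and so a stronger inhibitor, is therefore expected in this assay, though the size is uncertain. The expected change is an at least 5.0-fold lower number from compound 1 to compound 4 (0.69 log units; beyond the scatter). For compound 4 the estimated value is 200 nM, with an expected range of 40 nM to 1000 nM.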

Compound 4, half-maximal inhibitory concentration: 71.1 nM
Compound 4: middle estimate off by 2.8-fold (0.45 log units), on the high side, and the stated range covers the measured number.
By their numbers in this assay, from the lowest: compound 2; then compounds 3 and 4 (each within the scatter of the next). At a limit, above all of these: compound 1.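

For the compounds shown here, on the shared core, the group on the amide-type nitrogen in the ring matters far more than the earlier compounds suggested: in this assay, 4-fluoro-2-methoxyphenyl in place of 2,5-dimethoxyphenyl gives an at least 14-fold lower number from compound 1 to compound 4 (1.14 log units; beyond the scatter), a large step beside the modest 2.9-fold higher number from compound 2 to compound 3 (0.46 log units; beyond the scatter). Both groups have one six-membered aromatic ring of carbon only, so changing only what that ring carries can be enough to shift the value strongly. As far as these compounds go, the true size of the step remains unknown, since compound 1 gives only a limit and not a number: the limit of > 1000 nM in this assay, at which 1 of the 4 values shown sits.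

The compounds shown cannot separate the gain of fluorine from the loss of one methoxy group, as both happen in this single step. They also leave open how a chlorine atom or an amine on that ring would fare.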